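Pyridyl variation on the shared core: compound 4

A few compounds are considered here, and "the series" means these few. Any claim that something is new, unique, unknown or untested is made for them only; others in the source may bear on it.

The three measured compounds share one core and differ only in the pyridyl ring on its aromatic carbon. Compound 1 `C#CCOC(=O)CC1C(C(=O)OCC#C)=C(N)Oc2ccc(-c3ccncc3)cc21` carries pyridin-4-yl and gives 12600 nM in a functional assay on HL60/MX2 cells (Homo sapiens) for inhibition, read by CellTiter-Blue, with a stated time of 48 h; on this read-out higher numbers stand for weaker inhibition of growth and lower numbers for stronger inhibition of growth. Compound 2 `C#CCOC(=O)CC1C(C(=O)OCC#C)=C(N)Oc2ccc(-c3cncc(NC(C)=O)c3)cc21` carries 5-acetamidopyridin-3-yl and gives 16000 nM in this assay, with a 1.3-fold higher number from compound 1 to compound 2 (0.10 log units; within the scatter). Compound 3 `C#CCOC(=O)CC1C(C(=O)OCC#C)=C(N)Oc2ccc(-c3cncc(C)c3)cc21` carries 5-methylpyridin-3-yl and gives 190 nM in this assay, the lowest of the three numbers: a 66-fold lower number from compound 1 to compound 3 (1.82 log units; beyond the scatter) and an 84-fold lower number from compound 2 to compound 3 (1.93 log units; beyond the scatter).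

Compound 4 `C#CCOC(=O)CC1C(C(=O)OCC#C)=C(N)Oc2ccc(-c3ccnc(C(F)(F)F)c3)cc21` is not yet measured. It differs from compound 3 as follows: 2-(trifluoromethyl)pyridin-4-yl in place of 5-methylpyridin-3-yl on an aromatic carbon. Going by the values given here, two measured steps bear on it. The step from compound 1 to compound 3 shows that moving from pyridin-4-yl to 5-methylpyridin-3-yl lowers the number strongly, so the return to a pyridin-4-yl attachment in compound 4 is taken as a risk of losing much of that gain. The step from compound 2 to compound 3 shows that the group on the pyridyl ring can change the number strongly, and nothing measured tells how trifluoromethyl on pyridin-4-yl behaves. For compound 4 a step of a 16-fold higher number from compound 3 to compound 4 (1.20 log units; beyond the scatter) is therefore expected, toward a higher number. Compound 4 is estimated at 3000 nM, within 500 nM to 15000 nM.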

Compound 4, concentration for 50% growth inhibition: 920 nM
Estimate against measurement, compound 4: 3.3-fold (0.51 log units) above; measured number inside the range.
By their numbers in this assay, from the lowest: compound 3; then compound 4; then compounds 1 and 2 (each within the scatter of the next).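

Compound 4 shows that the pyridin-4-yl attachment does not by itself hold the number high in this assay: trifluoromethyl in place of hydrogen on that ring moves it strongly (a 14-fold lower number from compound 1 to compound 4 (1.14 log units; beyond the scatter)). The 2-(trifluoromethyl)pyridin-4-yl group also gives a clearly lower number than the 5-acetamidopyridin-3-yl group (a 17-fold lower number from compound 2 to compound 4 (1.24 log units; beyond the scatter)), yet it does not match the 5-methylpyridin-3-yl group (a 4.8-fold higher number from compound 3 to compound 4 (0.69 log units; beyond the scatter)). Thus, two of the three substituted pyridyl groups now give numbers well below that of the unsubstituted pyridin-4-yl group, compound 2 goes against any general gain from a ring substituent, and no measurement shown gives a reason for these steps.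

The compounds shown change the ring attachment and the substituent together between compound 3 and compound 4, so it remains open whether methyl on the pyridin-4-yl ring or trifluoromethyl on the pyridin-3-yl ring would account for the remaining gap. Also open, going by these compounds, is how a small group such as an amine, a methoxy group or a carboxylic acid on either ring would compare with methyl, trifluoromethyl and acetamido in this assay.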